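Swapping the amide cap for a plain alkyl chain

The source may hold more compounds than are shown below. What is called first, only, known or untested is meant among the compounds shown, and "the series" means these compounds.

Compound 1, `O=C(CN1CCCC1)N1CCC(NS(=O)(=O)c2cc(S(=O)(=O)c3ccccc3)ccc2C(F)(F)F)CC1`: 190 nM
Compound 2, `CC(C)(C)C(=O)N1CCC[C@H]1C(=O)N1CCC(NS(=O)(=O)c2cc(S(=O)(=O)c3ccccc3)ccc2C(F)(F)F)CC1`: 270 nM
Compound 3, `O=C([C@@H]1CCCN1C(=O)c1ccncc1)N1CCC(NS(=O)(=O)c2cc(S(=O)(=O)c3ccccc3)ccc2C(F)(F)F)CC1`: 350 nM

Three compounds share one core and differ only in the group hung on the piperidine amide. In a functional assay on U2OS cells for antagonist activity at proto-oncogene Wnt-3 (Homo sapiens), read by a luciferase reporter, with a stated time of 18 h (on this read-out higher numbers stand for an effect only at larger amounts of compound and lower numbers for an effect already at smaller amounts), compound 1 gives 190 nM, compound 2 gives 270 nM and compound 3 gives 350 nM. Compound 3 carries the highest of the three numbers, yet neither step that leads to it counts as a real change: a 1.4-fold higher number from compound 1 to compound 2 (0.15 log units; within the scatter) and a 1.3-fold higher number from compound 2 to compound 3 (0.11 log units; within the scatter). The values of compound 1 and compound 3 likewise sit within the scatter of each other, so all three are best read as one level.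

Compound 4, `CC(C)(C)CCN1CCC[C@H]1C(=O)N1CCC(NS(=O)(=O)c2cc(S(=O)(=O)c3ccccc3)ccc2C(F)(F)F)CC1`, is built from compound 3 by 3,3-dimethylbutyl in place of (pyridin-4-yl)carbonyl on an amine nitrogen in a ring. The two measured steps are the ones that bear on it, since each also reworked the cap on this pyrrolidine nitrogen, and both stayed inside the scatter. For the measured compounds named here, neither, however, removed the carbonyl from that nitrogen, which compound 4 does; the data give no step of that kind. On that basis compound 4 is expected to stay close to compound 3, with no change at the digits printed from compound 3 to compound 4 (within the scatter) as the estimated step and no change beyond the scatter. The estimate for compound 4 is therefore 350 nM, within a range from 120 nM to 1000 nM.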

Compound 4, half-maximal effective concentration: 450 nM
Compound 4: the middle estimate sits 1.3-fold (0.11 log units) below what was measured; the measured number falls inside the stated range.
By their numbers in this assay, from the lowest: compounds 1, 2, 3 and 4 (each within the scatter of the next, the first and the last beyond it).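

At the amine nitrogen in the five-membered ring, the cap need not hold a carbonyl or a ring: in this assay, 3,3-dimethylbutyl in place of (pyridin-4-yl)carbonyl gives a 1.3-fold higher number from compound 3 to compound 4 (0.11 log units; within the scatter), and in place of (tert-butyl)carbonyl it gives a 1.7-fold higher number from compound 2 to compound 4 (0.22 log units; within the scatter), so both steps that remove the carbonyl from this nitrogen stay within the scatter. For the compounds shown here, the one step beyond the scatter, and a modest one, is a 2.4-fold higher number from compound 1 to compound 4 (0.37 log units; beyond the scatter), but it replaces the whole (pyrrolidin-1-yl)methyl group with 1-(3,3-dimethylbutyl)pyrrolidin-2-yl, so it cannot be assigned to the 3,3-dimethylbutyl chain alone. No separate measurement shown here accounts for how little the number moves when this nitrogen loses its carbonyl.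

Still open, from the compounds shown here alone, is whether this nitrogen keeps the same level with a shorter ethyl chain, a longer straight chain, or a chain ending in an amine or a carboxylic acid. Also open, going by these compounds, is whether the same swap would behave alike on a core carrying something other than the trifluoromethyl group, as all four compounds share that part.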